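A Longer Alkenyl Amide on Two Inactive Compounds

The source may hold more compounds than are shown below. What is called first, only, known or untested is meant among the compounds shown, and "the series" means these compounds.

Compound 1 `C=CC(=O)Nc1cccc(Oc2nc(Nc3ccn(C)n3)nc3c2CSCC3)c1`: > 50000 nM
Compound 2 `C=CC(=O)Nc1cccc(Oc2nc(Nc3cccc(OC)c3)nc3c2CSCC3)c1`: > 50000 nM

In a functional assay on MCF7 cells (Homo sapiens) for antiproliferative activity, read by MTT assay, with a stated time of 72 h (a lower number here means a stronger inhibitor, a higher number a weaker inhibitor), compound 1 reaches only the limit of the assay, > 50000 nM. In this assay compound 2 likewise sits at a limit, > 50000 nM. The step that the two limits leave unreadable from compound 1 to compound 2 is therefore unreadable, and the limit of > 50000 nM in this assay, at which 2 of the 2 values shown sit, is all the evidence on hand. Compound 3 `COc1cccc(Nc2nc3c(c(Oc4cccc(NC(=O)/C=C/C(C)C)c4)n2)CSCC3)c1` differs from compound 2 by 3-methylbut-1-en-1-yl in place of vinyl on a carbonyl carbon. Going by the values given here, no measured step touches this position. Compound 3 is expected to give 50000 nM, within 20000 nM to 120000 nM. The expected step is a number no higher from compound 2 to compound 3 (the limit leaves the size open), probably again a limit.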

Compound 3, half-maximal inhibitory concentration: 21800 nM
The estimate for compound 3 lay 2.3-fold (0.36 log units) above the measured number; the measured number falls inside the stated range.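

Unlike the step between compound 1 and compound 2, which cannot be read, putting 3-methylbut-1-en-1-yl in place of vinyl on the carbonyl carbon gives a readable change in this assay, with an at least 2.2-fold lower number from compound 2 to compound 3 (0.36 log units; beyond the scatter). This position therefore responds to the change, and the series now has a number rather than only a limit. The size of the step remains a bound, because compound 2 rests at a limit: the limit of > 50000 nM in this assay, at which 2 of the 3 values shown sit.

Going by these compounds, whether a longer saturated chain or a dimethylamino group on this carbonyl carbon would lower the number further stays open. So does whether the same change would act alike on compound 1, which carries 1-methyl-1H-pyrazol-3-yl.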